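Methylating the inner nitrogen of a cyanoguanidine chain

A few compounds are considered here, and "the series" means these few. Any claim that something is new, unique, unknown or untested is made for them only; others in the source may bear on it.

Four compounds share one core, a phenyl-bearing ring carrying a saturated chain that ends in a cyanoguanidine. For the measured compounds named here, compound 1 is `C/N=C(\NC#N)NCCCCn1nc(-c2ccccc2)ccc1=O`; in a functional assay on the whole organism (stomach) with Rattus norvegicus as the target (a higher number here means that more compound is needed for the effect, a lower number that less compound is needed), compound 1 gives 32.4 mg/kg, the lowest of the two numbers known. Compound 3, `CC/N=C(/NC#N)NCCCn1nc(-c2ccccc2)ccc1=O`, gives 78.3 mg/kg in this assay. Compound 2 is `C/N=C(/NC#N)NCCCn1nc(-c2ccccc2)ccc1=O`, and for compound 2 this assay reports only a limit, > 100 mg/kg.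

Compound 4, `C/N=C(/NC#N)N(C)CCCCn1nc(-c2ccccc2)ccc1=O`, has not yet been measured. Relative to compound 1 it shows (a group of 8 heavy atoms (4 carbon, 4 nitrogen; no ring) in place of a group of 7 heavy atoms (3 carbon, 4 nitrogen; no ring), on a saturated chain carbon, four bonds along the chain from an aromatic nitrogen).

Going by the values given here, two measured steps bear on this. Shortening the chain gave an at least 3.0-fold higher number from compound 1 to compound 2 (0.48 log units; beyond the scatter), and adding a methyl to the other end of the cyanoguanidine gave a 2.4-fold higher number from compound 1 to compound 3 (0.38 log units; beyond the scatter). Among the compounds with values here, both changes to the chain end of compound 1 raised the number, so a modest rise beyond the scatter is expected here too, though neither step is the same change as the one in compound 4.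

Compound 4 is therefore estimated at 70 mg/kg, with a range from 30 mg/kg to 160 mg/kg, meaning an expected step of a 2.2-fold higher number from compound 1 to compound 4 (0.33 log units; beyond the scatter).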

Compound 4, dose for half-maximal effect: > 100 mg/kg
Compound 4: a limit, no number; the forecaster's own chance of this, stated with the estimate: 25%; at least 1.4-fold (0.15 log units) between middle value and limit.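

Putting a methyl on the inner nitrogen of the cyanoguanidine, with the chain length unchanged, leaves 1 hydrogen-bond donor where there were 2, and in this assay the change gives an at least 3.0-fold higher number from compound 1 to compound 4 (0.48 log units; beyond the scatter). The earlier steps shown here altered the chain length and the far end of the cyanoguanidine, whereas this step shows that a change at the inner nitrogen also raises the number. The result for compound 4 is a limit and not a number, so the step gives only a floor, and its full size cannot be read: the limit of > 100 mg/kg in this assay, at which 2 of the 4 values shown sit.

These compounds cannot separate the effect of losing the hydrogen on this nitrogen from that of adding the methyl itself. They also leave open how an ethyl group on this nitrogen, or a chain longer than that of compound 1, would behave.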